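Adding a Methyl to the Piperidine Ring

This account rests on a few compounds, and the source may have more. Where it says the series, first, only, none or still open, it means among the compounds named here.

Compound 3 `COc1cc2c(Nc3nc4ccc(C(=O)Nc5c(C)cccc5C)cc4s3)ncnc2cc1OCCCN1CCCCC1` is the starting point. In a functional assay on DLD-1 cells (Homo sapiens) for cytotoxicity, read by WST assay, with a stated time of 72 h (a lower number here means a stronger inhibitor, a higher number a weaker inhibitor), compound 3 gives only a limit of the assay, > 100000 nM. Compound 2 `CCN(CC)CCCOc1cc2ncnc(Nc3nc4ccc(C(=O)Nc5c(C)cccc5C)cc4s3)c2cc1OC` also gives only a limit in this assay, > 100000 nM. The step that the two limits leave unreadable from compound 2 to compound 3 is therefore unreadable, and what the numbers do show is the limit of > 100000 nM in this assay, at which 2 of the 3 values shown sit. Going by the values given here, compound 1 `COc1cc2c(Nc3nc4ccc(C(=O)Nc5c(C)cccc5Cl)cc4s3)ncnc2cc1OCCCN1CCCCC1C`, which carries a chloro instead of a methyl on the amide-bearing ring and already holds the 2-methylpiperidin-1-yl group, gives 6700 nM in this assay; no single step connects it to compound 3, so its value can only be set beside the others.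

Compound 4 `COc1cc2c(Nc3nc4ccc(C(=O)Nc5c(C)cccc5C)cc4s3)ncnc2cc1OCCCN1CCCCC1C` differs from compound 3 by methyl in place of hydrogen on a saturated ring carbon. Among the compounds with values here, no measured step speaks directly to this change, since the one step available sits between two limits. The value of compound 1 shows that a compound bearing the same methylated ring can give a number rather than a limit, but it differs in a second place as well. The step of an at least 2.0-fold lower number from compound 3 to compound 4 (0.30 log units; that floor lies within the scatter) is therefore expected to be modest and uncertain in size. Compound 4 is estimated at 50000 nM, with a range from 10000 nM to 200000 nM.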

Compound 4, half-maximal inhibitory concentration: > 100000 nM
Compound 4: no number, only a limit (the forecaster's own chance of this, stated with the estimate: 40%); middle value at least 2.0-fold (0.30 log units) away from the limit.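

Compound 4 also stops at a limit of the assay in this assay, so the methyl on the saturated ring carbon, next to the ring nitrogen, does not by itself yield a readable number, and the steps from compound 2 and from compound 3 to compound 4 cannot be read. Going by these compounds alone, the one readable change lies elsewhere: methyl in place of chloro on an aromatic carbon gives an at least 14-fold higher number from compound 1 to compound 4 (1.17 log units; beyond the scatter), so with the 2-methylpiperidin-1-yl group held the same, the swap on the amide-bearing ring separates a measured number from a limit. Compound 1 is the only one that gives a number, and the others all stay at one limit: the limit of > 100000 nM in this assay, at which 3 of the 4 values shown sit.

The compounds shown leave open whether chloro on the amide-bearing ring would still give a number with a plain piperidin-1-yl or a diethylamino group in place of the 2-methylpiperidin-1-yl group, and whether bromo or fluoro would do the same as chloro. On these data alone, the effect of the ring methyl itself also stays open, as a limit gives compound 3 and compound 4 no order.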